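Fluoro to Methoxy on the Fused Ring of Compound 1

The source may report more compounds than this note shows. Statements on the series, on what has been measured and on what is new or still open speak of the compounds shown alone.

compound 1, `Cc1c(C(=O)Nc2ccc(Oc3ncnc4[nH]cc(-c5ccccc5)c34)c(F)c2)c(=O)c2cc(F)ccc2n1C`, > 10000 nM
compound 2, `CCc1c(C(=O)Nc2ccc(Oc3ncnc4[nH]cc(-c5ccccc5)c34)c(F)c2)c(=O)c2cc(C)ccc2n1C`, 78 nM

Compound 1 `Cc1c(C(=O)Nc2ccc(Oc3ncnc4[nH]cc(-c5ccccc5)c34)c(F)c2)c(=O)c2cc(F)ccc2n1C` is known only as a limit. In an assay on isolated protein for inhibition of tyrosine-protein kinase receptor UFO (Homo sapiens), read by FRET and Z'-LYTE, with a stated time of 1.5 h (a higher number here means a weaker inhibitor, a lower number a stronger inhibitor), compound 1 gives > 10000 nM, which is a limit of the assay and not a number (the limit of > 10000 nM in this assay, at which 1 of the 2 values shown sits). Going by the values given here, compound 2 `CCc1c(C(=O)Nc2ccc(Oc3ncnc4[nH]cc(-c5ccccc5)c34)c(F)c2)c(=O)c2cc(C)ccc2n1C` differs from compound 1 in more than one place, so no single step between the two can be traced. In this assay compound 2 gives 78 nM.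

Compound 3 `COc1ccc2c(c1)c(=O)c(C(=O)Nc1ccc(Oc3ncnc4[nH]cc(-c5ccccc5)c34)c(F)c1)c(C)n2C` carries one change from compound 1: methoxy in place of fluoro on an aromatic carbon. Among the compounds with values here, no measured step of one change is available, so the size of this step rests on expectation alone. Because compound 1 sits at the limit, the expected step of an at least 3.3-fold lower number from compound 1 to compound 3 (0.52 log units; beyond the scatter) is toward stronger inhibition, with a real chance that compound 3 also returns only a limit. Compound 3 is estimated at 3000 nM, within a range from 300 nM to 20000 nM.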

Compound 3, half-maximal inhibitory concentration: 99 nM
The estimate for compound 3 lay 30-fold (1.48 log units) above the measured number, and the stated range ends above it.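

In this assay compound 1 gives > 10000 nM, which is a limit of the assay and not a number. Methoxy in place of fluoro on this aromatic carbon, with nothing else changed, brings an at least 100-fold lower number from compound 1 to compound 3 (2.00 log units; beyond the scatter), so the group at this one position can by itself take a compound from the limit to a measured value. The full size of the step stays unknown because one end of it rests on a limit: the limit of > 10000 nM in this assay, at which 1 of the 3 values shown sits.

From the compounds shown here alone, what stays open is whether the step comes from the loss of fluoro or the entry of methoxy, and how a hydroxyl, a chloro or an ethoxy at this position would read in this assay. Compound 2 differs from compound 3 in more than one place, so it cannot settle this.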